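Ester in place of amide on the carbonyl carbon

The source may hold more compounds than are shown below. What is called first, only, known or untested is meant among the compounds shown, and "the series" means these compounds.

Compound 1 `CCCC(=O)C1=Cc2ccc(OC)cc2OC1c1cc(OC)c(OC)c(OC)c1` gives 11700 nM in a functional assay for inhibition of nuclear factor NF-kappa-B complex (Homo sapiens); on this read-out higher numbers stand for weaker inhibition and lower numbers for stronger inhibition. Compound 2 `CCCCNC(=O)C1=Cc2ccc(OC)cc2OC1c1cc(OC)c(OC)c(OC)c1` gives 25500 nM in this assay. Compound 3 `COc1ccc2c(c1)OC(c1cc(OC)c(OC)c(OC)c1)C(C(=O)N(C)C)=C2` reaches only a limit of the assay in this assay, > 50000 nM, so its position is known as a floor and not as a number (the limit of > 50000 nM in this assay, at which 1 of the 3 values shown sits). The measured steps are a 2.2-fold higher number from compound 1 to compound 2 (0.34 log units; beyond the scatter), an at least 4.2-fold higher number from compound 1 to compound 3 (0.63 log units; beyond the scatter) and an at least 1.9-fold higher number from compound 2 to compound 3 (0.29 log units; that floor lies within the scatter). Compound 4 `COc1ccc2c(c1)OC(c1cc(OC)c(OC)c(OC)c1)C(C(=O)OC(C)C)=C2` has not been measured; it differs from compound 3 as follows: isopropoxy in place of dimethylamino on a carbonyl carbon. Within the data shown here, no measured step exchanges dimethylamino for isopropoxy, so the bearing of the series is indirect: propyl on the carbonyl carbon gave the lowest number (compound 1), and both amides gave higher numbers. For compound 4 in this assay a value between that of compound 1 and the floor of compound 3 is expected. As a step this is expected to read an at least 2.0-fold lower number from compound 3 to compound 4 (0.30 log units; that floor lies within the scatter). The estimate for compound 4 is 25000 nM, with a range of 8000 nM to 70000 nM, and a further limit cannot be excluded.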

Compound 4, half-maximal inhibitory concentration: 11800 nM
Beside the measured number, compound 4's estimate is 2.1-fold (0.33 log units) above it, within the range that was stated.
By their numbers in this assay, from the lowest: compounds 1 and 4 (each within the scatter of the next); then compound 2. At a limit, above all of these: compound 3.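

In this assay, isopropoxy in place of dimethylamino on the carbonyl carbon gives an at least 4.2-fold lower number from compound 3 to compound 4 (0.62 log units; beyond the scatter); one end of this step is a limit of the assay, so the step stands only as a floor: the limit of > 50000 nM in this assay, at which 1 of the 4 values shown sits.

Isopropoxy in place of butylamino gives a 2.2-fold lower number from compound 2 to compound 4 (0.33 log units; beyond the scatter), so the change from amide to ester lowers the number against both amides shown, and no compound here goes against that. Isopropoxy in place of propyl gives a 1.0-fold higher number from compound 1 to compound 4 (0.00 log units; within the scatter), so the two groups are not told apart at this position in this assay.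

From the compounds shown here alone, it remains open whether a carboxylic acid or a longer alkoxy chain on the carbonyl carbon would move the number away from that of compounds 1 and 4. The order of the two amides also stays unsettled, with an at least 1.9-fold higher number from compound 2 to compound 3 (0.29 log units; that floor lies within the scatter).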